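This account rests on a few compounds, and the source may have more. Where it says the series, first, only, none or still open, it means among the compounds named here.

In a functional assay on HeLa cells (Homo sapiens) for antiproliferative activity, read by MTT assay, with a stated time of 72 h (on this read-out higher numbers stand for weaker inhibition and lower numbers for stronger inhibition), the three measured compounds stand as follows: compound 1 `O=C1O[C@H]([C@@H](O)Cn2cc(-c3ccc(Br)cc3)nn2)C(OCc2ccccc2)=C1OCc1ccccc1` gives 3910 nM; compound 2 `CCCCc1cn(C[C@H](O)[C@H]2OC(=O)C(OCc3ccccc3)=C2OCc2ccccc2)nn1` gives 18100 nM; compound 3 `CCCCCc1ccc(-c2cn(C[C@H](O)[C@H]3OC(=O)C(OCc4ccccc4)=C3OCc3ccccc3)nn2)cc1` gives 8390 nM.

Compound 3 thus holds the middle place of the three. Its nearest neighbour is compound 1, separated by a 2.1-fold higher number from compound 1 to compound 3 (0.33 log units; beyond the scatter), and its furthest is compound 2, separated by a 2.2-fold lower number from compound 2 to compound 3 (0.33 log units; beyond the scatter).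

Compound 4 `COc1ccccc1-c1cn(C[C@H](O)[C@H]2OC(=O)C(OCc3ccccc3)=C2OCc2ccccc2)nn1` differs from compound 3 by 2-methoxyphenyl in place of 4-pentylphenyl on an aromatic carbon. Within the data shown here, two measured steps bear on this change: the exchange of an alkyl chain for an aryl group, a 2.2-fold lower number from compound 2 to compound 3 (0.33 log units; beyond the scatter), and the exchange of one phenyl substituent for another, a 2.1-fold higher number from compound 1 to compound 3 (0.33 log units; beyond the scatter). Both were modest. Since compound 4 keeps an aryl group and only its substituent changes, a modest downward step, a 1.7-fold lower number from compound 3 to compound 4 (0.22 log units; within the scatter), is expected in this assay. Compound 4 is therefore estimated at 5000 nM, within a range from 2000 nM to 15000 nM.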

Compound 4, half-maximal inhibitory concentration: > 100000 nM
Compound 4: no number, only a limit (the forecaster's own chance of this, stated with the estimate: 5%); at least 20-fold (1.30 log units) between middle value and limit.
By their numbers in this assay, from the lowest: compound 1; then compound 3; then compound 2. At a limit, above all of these: compound 4.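

In this assay compound 4 gives > 100000 nM, which is a limit of the assay and not a number. The earlier aryl groups at this position gave measurable values, but 2-methoxyphenyl gives an at least 11-fold higher number from compound 3 to compound 4 (1.07 log units; beyond the scatter), an at least 25-fold higher number from compound 1 to compound 4 (1.40 log units; beyond the scatter) and an at least 5.5-fold higher number from compound 2 to compound 4 (0.74 log units; beyond the scatter). An aryl group here therefore does not by itself keep the activity, and the butyl chain does better than this one. Going by these compounds, whether the loss follows the methoxy group itself or its place on the phenyl ring stays open. How 4-methoxyphenyl or a plain phenyl would read here is also unknown.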